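Shortening a Phosphate Prodrug Chain and Rat Exposure

This account rests on a few compounds, and the source may have more. Where it says the series, first, only, none or still open, it means among the compounds named here.

Three compounds from one series have been examined in an ADME assay on the whole organism (strain Sprague-Dawley) for pharmacokinetics, with Rattus norvegicus as the target, read by LC-MS, with a stated time of 24 h, at a dose of 10 mg/kg by the oral route; a higher number here means more compound in the circulation at the dose given, a lower number less compound in the circulation. Compound 1 `C[C@@H](C1CC1)n1cc(Cl)nc(N(C(=O)OCC(C)(C)COP(=O)(O)O)c2c(Cl)cc(OC(F)F)cc2Cl)c1=O` gives a result of "below limit of detection" (no number reported), so no number is available for it. Compound 2 `C[C@@H](C1CC1)n1cc(Cl)nc(N(C(=O)OCOC(=O)CN(C)C)c2c(Cl)cc(OC(F)F)cc2Cl)c1=O` likewise gives "below limit of detection" (no number reported), again without a number. Going by the values given here, compound 3 `C[C@@H](C1CC1)n1cc(Cl)nc(N(C(=O)OCCCOP(=O)(O)O)c2c(Cl)cc(OC(F)F)cc2Cl)c1=O` is the only member of the set to give a measured value, and in this assay compound 3 gives 2570 ng.h/mL. Since the other two entries carry no number, compound 3 stands alone among the numbers shown, and no comparison between measured steps is available.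

Compound 4 `C[C@@H](C1CC1)n1cc(Cl)nc(N(COP(=O)(O)O)c2c(Cl)cc(OC(F)F)cc2Cl)c1=O` has not yet been measured. It differs from compound 3 by a group of 6 heavy atoms (1 carbon, 4 oxygen, 1 phosphorus; no ring) in place of a group of 11 heavy atoms (4 carbon, 6 oxygen, 1 phosphorus; no ring), on a nitrogen on an aromatic ring, in other words a group of 6 heavy atoms (1 carbon, 4 oxygen, 1 phosphorus; no ring) in place of a group of 11 heavy atoms (4 carbon, 6 oxygen, 1 phosphorus; no ring), on a nitrogen on an aromatic ring.

No step between two measured compounds is shown, so the expected size of the change rests only on the one value of compound 3. Compound 4 is estimated to give 3000 ng.h/mL, with a range from 800 ng.h/mL to 10000 ng.h/mL. The expected step from a 1.2-fold higher number from compound 3 to compound 4 (0.07 log units; within the scatter) is therefore small, in either direction, and not beyond the usual scatter.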

Compound 4, area under the concentration-time curve: 3200 ng.h/mL
Compound 4: middle estimate off by 1.1-fold (0.03 log units), on the low side; low and high end bracket the measured number.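

In this assay, putting the group of 6 heavy atoms in place of the group of 11 heavy atoms, on a nitrogen on an aromatic ring, gives a 1.2-fold higher number from compound 3 to compound 4 (0.10 log units; within the scatter), so the two compounds cannot be told apart in this read-out. Going by these compounds alone, this is the first pair at this nitrogen with a number on both sides, and it shows that the group can lose the atoms that separate these two compounds with no change in exposure beyond the scatter, whereas the steps to compound 1 and compound 2 cannot be read, as those results carry no number. Nothing measured here bears on why the two numbers agree.

The compounds shown leave open whether a longer chain ending in phosphate on this nitrogen would keep such a number, and whether an amine or a carboxylic acid in place of the phosphate would do so. They also leave open how far this one pair, read at a single oral dose in one rat strain, holds for other groups at this position.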